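The compounds below may be only part of what the source reports. "The series", "measured", "known", "first", "only" and "open" are said of these compounds alone.

Compound 1 `Cc1ccc(OCC(=O)N(Cc2cccs2)c2ncco2)cc1` gives 0.3 nM in an assay on HEK293 cells for agonist activity at transient receptor potential cation channel subfamily M member 8 (Homo sapiens), read by fluorescence and calcium flux, with a stated time of 15 min; a lower number here means that less compound is needed, a higher number that more compound is needed for the effect. Compound 2 `C=CCN(Cc1cccs1)C(=O)COc1ccc(C)cc1` gives 20 nM.

Compound 2 thus carries the highest number of the two, with compound 1 giving the lower one. Compound 3 `Cc1ccc(OCC(=O)N(Cc2cccs2)c2ccon2)cc1` differs from compound 2 in one place: 1,2-oxazol-3-yl in place of allyl on an amide-type nitrogen. Going by the values given here, the only measured step that bears on this is a 67-fold higher number from compound 1 to compound 2 (1.82 log units; beyond the scatter), where a five-membered aromatic ring gave way to allyl. Returning a related ring is expected to reverse most of that, so a large drop is expected: a 20-fold lower number from compound 2 to compound 3 (1.30 log units; beyond the scatter). Compound 3 is therefore estimated at 1 nM, within 0.2 nM to 5 nM.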

Compound 3, half-maximal effective concentration: 2 nM
Compound 3: the middle estimate sits 2.0-fold (0.30 log units) below what was measured, within the range that was stated.
By their numbers in this assay, from the lowest: compound 1; then compound 3; then compound 2.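

At this amide-type nitrogen, a second five-membered aromatic ring also gives a much lower number than allyl (a 10-fold lower number from compound 2 to compound 3 (1.00 log units; beyond the scatter)), so the earlier gain is not confined to 1,3-oxazol-2-yl. The two rings are still not interchangeable: moving to 1,2-oxazol-3-yl costs a modest but real amount (a 6.7-fold higher number from compound 1 to compound 3 (0.82 log units; beyond the scatter)). Nothing available explains either step. Still open, from the compounds shown here alone, is whether the low numbers require an aromatic ring at all, and how a saturated ring such as cyclopentyl or a six-membered aromatic ring such as pyridin-2-yl would compare.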